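This account rests on a few compounds, and the source may have more. Where it says the series, first, only, none or still open, it means among the compounds named here.

Measured so far in a functional assay on MDA-MB-231 cells (Homo sapiens) for antiproliferative activity, read by MTT assay, with a stated time of 48 h; on this read-out higher numbers stand for weaker inhibition and lower numbers for stronger inhibition:
compound 1 `O=C(/C=C/c1ccccc1)Nc1cc2c(Nc3ccc(F)c(Cl)c3)ncnc2s1` gives 7600 nM
compound 2 `O=C(/C=C/c1ccccc1)Nc1cc2c(Nc3cccc(Cl)c3F)ncnc2s1` gives 3930 nM

Compound 2 cannot be separated from compound 1: the step of a 1.9-fold lower number from compound 1 to compound 2 (0.29 log units; within the scatter) is all the series shows so far. Compound 3 `C#Cc1cccc(Nc2ncnc3sc(NC(=O)/C=C/c4ccccc4)cc23)c1` is not yet measured, and the change leading to it is 3-ethynylphenyl in place of 3-chloro-2-fluorophenyl on a nitrogen on an aromatic ring with the rest unchanged. Among the measured compounds shown here, the single measured step also alters the group on that nitrogen, yet no measured compound holds 3-ethynylphenyl. No step beyond the scatter is therefore expected in this assay and the expected change is a 1.3-fold higher number from compound 2 to compound 3 (0.10 log units; within the scatter) in this estimate. Compound 3 is estimated at 5000 nM with an expected range of 2000 nM to 12000 nM on this read-out.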

Compound 3, half-maximal inhibitory concentration: 5050 nM
Compound 3: middle estimate off by 1.0-fold (0.00 log units), on the low side, within the range that was stated.
By their numbers in this assay, from the lowest: compounds 2, 3 and 1 (each within the scatter of the next).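

In this assay, 3-ethynylphenyl on a nitrogen on an aromatic ring gives a 1.3-fold higher number from compound 2 to compound 3 (0.11 log units; within the scatter) and a 1.5-fold lower number from compound 1 to compound 3 (0.18 log units; within the scatter), so this group cannot be separated from either chloro-fluoro group. Replacing both fluorine and chlorine with an all-carbon group containing a triple bond therefore produces no readable step at this position. No available data explain why these groups read alike.

Open, as far as these compounds go, is whether an aminophenyl or carboxyphenyl group here would give a step beyond the scatter. Also open, from the compounds shown here alone, is whether these groups stay inseparable with a different amide on the shared core.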